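Cyano on the pyrazole carbon of the aryl-urea series

This account rests on a few compounds, and the source may have more. Where it says the series, first, only, none or still open, it means among the compounds named here.

Compound 3 `CN(CCN(C)C(=O)n1cccn1)Cc1ccc(OCc2ccccc2)cc1` holds the lowest number in an assay on membranes from brain for binding affinity to Fatty-acid amide hydrolase 1 (Mus musculus), read by fluorescence, with stated times of 1 h and 30 min (a lower number here means a stronger inhibitor, a higher number a weaker inhibitor), among the three measured: compound 3 gives 510 nM, compound 1 `Cc1cnn(C(=O)N2CCCCC2)c1` gives 2200 nM, and compound 2 `Cc1cnn(C(=O)N(C)CCN(C)Cc2ccc(OCc3ccccc3)cc2)c1` gives 8700 nM. Within the data shown here, the only step measured here concerns the same aromatic carbon: a 17-fold lower number from compound 2 to compound 3 (1.23 log units; beyond the scatter). Compound 4 `CN(CCN(C)C(=O)n1cc(C#N)cn1)Cc1ccc(OCc2ccccc2)cc1` reverses this direction with another group, (cyano in place of hydrogen on an aromatic carbon). Among the measured compounds shown here, no step with a cyano group exists, so the methyl step shows only that a substituent at this carbon can move this assay strongly, not where cyano will land. The estimate for compound 4 is therefore set near compound 3 with a wide range, a 1.2-fold higher number from compound 3 to compound 4 (0.07 log units; within the scatter), giving an expected value of 600 nM between 80 nM and 5000 nM.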

Compound 4, half-maximal inhibitory concentration: 120 nM
Estimate against measurement, compound 4: 5.0-fold (0.70 log units) above; measured number inside the range.
By their numbers in this assay, from the lowest: compound 4; then compound 3; then compound 1; then compound 2.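

At this aromatic carbon, a substituent can lower the number in this assay as well as raise it: hydrogen to cyano gives a 4.3-fold lower number from compound 3 to compound 4 (0.63 log units; beyond the scatter), while methyl sits on the weaker side of hydrogen. Cyano in place of methyl gives a 73-fold lower number from compound 2 to compound 4 (1.86 log units; beyond the scatter), so the direction depends on which group occupies this carbon, not merely on its being occupied. Nothing available explains why the two groups part in this way.

On these data alone, whether an amine, a carboxylic acid or chloro at this carbon would follow cyano or methyl remains open. Also open, as far as these compounds go, is whether cyano would lower the number on compound 1 as well.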